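Carbonyl substituent exchange, compound 3 to compound 4

The source may report more compounds than this note shows. Statements on the series, on what has been measured and on what is new or still open speak of the compounds shown alone.

Compound 1 `N#CC1=C(N)N(c2ccc(S(N)(=O)=O)cc2)C2=C(C(=O)CCC2)C1c1ccc(Cl)cc1Cl` gives 40% in a functional assay on Ehrlich cells (Mus musculus) for cytotoxicity, read by trypan blue exclusion, with a stated time of 2 h, tested at 10 ug/mL; on this read-out lower numbers stand for a weaker effect and higher numbers for a stronger effect at the one concentration tested. Acylation of the amine nitrogen gives compound 2 `CC(Cl)CC(=O)NC1=C(C#N)C(c2ccc(Cl)cc2Cl)C2=C(CCCC2=O)N1c1ccc(S(N)(=O)=O)cc1`, which gives 20%, and compound 3 `N#CC1=C(NC(=O)/C=C/c2ccccc2)N(c2ccc(S(N)(=O)=O)cc2)C2=C(C(=O)CCC2)C1c1ccc(Cl)cc1Cl`, which gives 30%; compound 3 thus stands second highest of the three numbers, within the scatter of compound 1 and of compound 2. Compound 4 `N#CC1=C(NC(=O)c2ccc([N+](=O)[O-])cc2)N(c2ccc(S(N)(=O)=O)cc2)C2=C(C(=O)CCC2)C1c1ccc(Cl)cc1Cl` is not yet measured; it differs from compound 3 by 4-nitrophenyl in place of 2-phenylethenyl on a carbonyl carbon. The step that bears most directly on it, a number 10 percentage points higher from compound 2 to compound 3 (within the scatter), exchanged groups on the same carbonyl carbon and stayed within the scatter; a number 10 percentage points lower from compound 1 to compound 3 (within the scatter) also stayed within the scatter, and only a number 20 percentage points lower from compound 1 to compound 2 (beyond the scatter) went beyond it. A step of no change at the digits printed from compound 3 to compound 4 (within the scatter) is therefore expected, nothing beyond the scatter. Compound 4 is estimated at 30%, range 15% to 45%.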

Compound 4, a percentage reported as activity, at one concentration (the size of the read-out at that concentration, not a potency): 40%
Compound 4: middle estimate off by 10 percentage points, on the low side; measured number inside the range.
By their numbers in this assay, from the lowest: compounds 2, 3, 1 and 4 (each within the scatter of the next, the first and the last beyond it).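

In this assay, for the compounds shown here, the group on this carbonyl carbon can move the number: 4-nitrophenyl in place of 2-chloropropyl gives a number 20 percentage points higher from compound 2 to compound 4 (beyond the scatter) and is the first exchange there to pass the scatter. Against 2-phenylethenyl the same group gives a number 10 percentage points higher from compound 3 to compound 4 (within the scatter) and (4-nitrophenyl)carbonyl on the amine nitrogen gives no change at the digits printed from compound 1 to compound 4 (within the scatter) so acylation there does not always lower the number, as compound 2 alone suggested. No available evidence bears on these differences.

Open, from the compounds shown here alone, is whether a phenyl carrying an amine or a carboxylic acid in place of the nitro group, or a longer chain on the carbonyl, holds this reading.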